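The compounds below may be only part of what the source reports. "The series", "measured", "known", "first", "only" and "open" are said of these compounds alone.

Measured so far:
compound 1 `COc1ccc(-n2cc(COc3ccc(/C=C/C(=O)c4cc5c(cc4O)OC(C)(C)CC5)cc3)nn2)c([N+](=O)[O-])c1` — "not active" (no number reported)
compound 2 `CC(=O)c1ccc(-n2cc(COc3ccc(/C=C/C(=O)c4ccc5c(c4O)CCC(C)(C)O5)cc3)nn2)cc1` — 89600 nM

In a functional assay on IMR-32 cells (Homo sapiens) for antiproliferative activity, read by MTT assay (on this read-out lower numbers stand for stronger inhibition and higher numbers for weaker inhibition), compound 1 gives "not active" (no number reported), so no number places it on the scale. In this assay compound 2 gives 89600 nM, a weak result. Compound 3 `CC1(C)CCc2cc(C(=O)/C=C/c3ccc(OCc4cn(Cc5ccc([N+](=O)[O-])cc5)nn4)cc3)c(O)cc2O1` differs from compound 1 in one place: 4-nitrobenzyl in place of 4-methoxy-2-nitrophenyl on an aromatic nitrogen. For the measured compounds named here, no measured pair shows this change, and compound 1 offers no number to step from, so the expected shift in this assay cannot be sized; weak inhibition near compound 2 seems likely. Compound 3 is estimated at 100000 nM, expected between 30000 nM and 300000 nM.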

Compound 3, half-maximal inhibitory concentration: 108000 nM
Beside the measured number, compound 3's estimate is 1.1-fold (0.03 log units) below it; low and high end bracket the measured number.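

For the compounds shown here, compound 1 has no number, so no step from it to compound 3 can be read. On these data alone, what swapping 4-methoxy-2-nitrophenyl for 4-nitrobenzyl does to activity stays open. No evidence here explains either result.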